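Replacing the amide substituent on a weak inhibitor series

This account rests on a few compounds, and the source may have more. Where it says the series, first, only, none or still open, it means among the compounds named here.

Compound 1 `Cn1ccc2ccc(-c3cc(Nc4ccccc4S(N)(=O)=O)cc4nccnc34)cc21`: 37600 nM
Compound 2 `Cn1ccc2ccc(-c3cc(Nc4cnccc4C(=O)NCc4cncnc4)cc4nccnc34)cc21`: 49500 nM

Within the data shown here, only two compounds have been measured in an assay on lysate for inhibition of 6-phosphofructo-2-kinase/fructose-2,6-bisphosphatase 3 (Homo sapiens), with stated times of 0.5 min and 45 min (on this read-out lower numbers stand for stronger inhibition and higher numbers for weaker inhibition), and both sit at the weak end of the scale. Compound 2 gives 49500 nM, the highest of the two numbers, but its nearest neighbour, compound 1 at 37600 nM, lies within the scatter, so no order between them can be drawn.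

Compound 3 `CN1CCC(N(C)C(=O)c2ccncc2Nc2cc(-c3ccc4ccn(C)c4c3)c3nccnc3c2)C1` keeps the whole of compound 2 except at the carbonyl carbon, where the change is methyl(1-methylpyrrolidin-3-yl)amino in place of ((pyrimidin-5-yl)methyl)amino on a carbonyl carbon. Among the measured compounds shown here, no measured pair shows this kind of change, so nothing in the data points to a direction. Because compound 2 gives 49500 nM, compound 3 is expected to remain a weak inhibitor, with a step of a 1.2-fold lower number from compound 2 to compound 3 (0.09 log units; within the scatter) that is not expected to exceed the scatter. Compound 3 is estimated at 40000 nM, within a range from 10000 nM to 160000 nM.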

Compound 3, half-maximal inhibitory concentration: 39700 nM
Beside the measured number, compound 3's estimate is 1.0-fold (0.00 log units) above it, within the range that was stated.
By their numbers in this assay, from the lowest: compounds 1, 3 and 2 (each within the scatter of the next).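

Putting methyl(1-methylpyrrolidin-3-yl)amino in place of ((pyrimidin-5-yl)methyl)amino on a carbonyl carbon gives a 1.2-fold lower number from compound 2 to compound 3 (0.10 log units; within the scatter) in this assay and so leaves the number where it was, at the weak end of the scale. This exchange swaps one six-membered aromatic ring with 2 hetero atoms for one five-membered non-aromatic ring with 1 hetero atom, and 1 hydrogen-bond donor for 0, yet this pair shows no step beyond the scatter. Nothing measured here offers an explanation for this outcome. On these data alone, whether a small dimethylamino group or a longer chain ending in a primary amine on the same carbonyl carbon would move the number beyond the scatter remains open. So does whether a carboxylic acid in place of the whole ((pyrimidin-5-yl)methyl)carbamoyl group would do so.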